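A few compounds are considered here, and "the series" means these few. Any claim that something is new, unique, unknown or untested is made for them only; others in the source may bear on it.

Of the compounds shown here, three with a shared core have been measured so far. In a functional assay on PC-3 cells (Homo sapiens) for cytotoxicity, read by MTT assay, with a stated time of 72 h (a higher number here means a weaker inhibitor, a lower number a stronger inhibitor), compound 1 `CNC(=O)c1cc(Oc2ccc(C(=O)/C=C/c3ccc(Cl)c(Cl)c3)cc2)ccn1` gives 8260 nM and compound 2 `CNC(=O)c1cc(Oc2ccc(C(=O)/C=C/c3ccc(Br)cc3)cc2)ccn1` gives 18500 nM while compound 3 `CNC(=O)c1cc(Oc2ccc(C(=O)/C=C/c3ccc([N+](=O)[O-])cc3)cc2)ccn1` gives 11100 nM and so lies within the usual scatter of both others.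

The next compound, compound 4 `CNC(=O)c1cc(Oc2ccc(C(=O)/C=C/c3ccc(F)cc3Cl)cc2)ccn1`, differs from compound 3 in a single group: 2-chloro-4-fluorophenyl in place of 4-nitrophenyl on a double-bonded chain carbon bound to a double-bonded chain carbon. That is, 2-chloro-4-fluorophenyl stands in place of 4-nitrophenyl, on a double-bonded chain carbon bound to a double-bonded chain carbon.

The three measured compounds differ from one another at this same place, so their steps are the best guide available. Two of them stay within the scatter: a 1.3-fold higher number from compound 1 to compound 3 (0.13 log units; within the scatter) and a 1.7-fold lower number from compound 2 to compound 3 (0.22 log units; within the scatter) are too small to read as real differences. Only a 2.2-fold higher number from compound 1 to compound 2 (0.35 log units; beyond the scatter) goes beyond it, and that step is modest. None of the three compounds carries the entering group, so the data give no direct measure of it, and a surprise remains possible.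

Given such small steps, the expected change is a 1.1-fold lower number from compound 3 to compound 4 (0.02 log units; within the scatter) and no step beyond the scatter is expected in this assay in either direction. Compound 4 is therefore estimated at 10500 nM with an expected range (4500 nM to 24000 nM).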

Compound 4, half-maximal inhibitory concentration: 4760 nM
Estimate against measurement, compound 4: 2.2-fold (0.34 log units) above; measured number inside the range.
By their numbers in this assay, from the lowest: compounds 4, 1, 3 and 2 (each within the scatter of the next, the first and the last beyond it).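

At this place, on a double-bonded chain carbon bound to a double-bonded chain carbon, swapping the aryl group gives a change beyond the scatter in this assay: 2-chloro-4-fluorophenyl in place of 4-nitrophenyl gives a 2.3-fold lower number from compound 3 to compound 4 (0.37 log units; beyond the scatter), and in place of 4-bromophenyl it gives a 3.9-fold lower number from compound 2 to compound 4 (0.59 log units; beyond the scatter), the largest step among the compounds shown. Against 3,4-dichlorophenyl the result is a 1.7-fold lower number from compound 1 to compound 4 (0.24 log units; within the scatter), so 2-chloro-4-fluorophenyl and 3,4-dichlorophenyl cannot be told apart in this assay. Compound 1 and compound 4 both carry chlorine, yet compound 3, which has none, stays within the scatter of compound 1, so chlorine alone does not sort these results.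

No evidence is available on why the numbers differ at this place. The compounds shown also leave open whether the chlorine or the fluorine of 2-chloro-4-fluorophenyl matters more, which a phenyl carrying only one of them could test, and how a ring bearing an amine or a carboxylic acid would read here.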